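This account rests on a few compounds, and the source may have more. Where it says the series, first, only, none or still open, it means among the compounds named here.

Measured compounds:
Compound 1 `COc1ccc(N(C)c2nc(C)nc3ccccc23)cc1OCCC[Se]C#N`, in a functional assay on HCT-116 cells (Homo sapiens) for inhibition, read by MTT assay, with a stated time of 48 h (on this read-out higher numbers stand for weaker inhibition and lower numbers for stronger inhibition), compound 1 gives 852 nM.
Compound 2 `COc1ccc(N(C)c2nc(C)nc3ccccc23)cc1C(=O)OCCCC[Se]C#N`, in this assay compound 2 gives 662 nM.

Compound 2 holds the lowest of the two numbers measured in this assay, but its nearest neighbour, compound 1, sits only a 1.3-fold lower number from compound 1 to compound 2 (0.11 log units; within the scatter) away, so the two cannot be told apart on these data. The account now turns to compound 3 `COc1ccc(N(C)c2nc(C)nc3ccccc23)cc1OCCCC[Se]C#N`, which has not yet been measured in this assay. Against compound 2 the change is a group of 8 heavy atoms (5 carbon, 1 nitrogen, 1 oxygen, 1 selenium; no ring) in place of a group of 10 heavy atoms (6 carbon, 1 nitrogen, 2 oxygen, 1 selenium; no ring), on an aromatic carbon. For the measured compounds named here, the one measured step that bears on this change is the one from compound 1 to compound 2, which showed a 1.3-fold lower number from compound 1 to compound 2 (0.11 log units; within the scatter); compound 3 shares its ether linkage with compound 1 and its chain length with compound 2, so it stands between the two measured compounds in structure. Going by the values given here, with only that step to go on, no movement beyond the scatter is expected, and the estimate for compound 3 is 750 nM, with a range from 350 nM to 1600 nM. The step this estimate implies in this assay is a 1.1-fold higher number from compound 2 to compound 3 (0.05 log units; within the scatter).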

Compound 3, half-maximal inhibitory concentration: 512 nM
Compound 3: middle estimate off by 1.5-fold (0.17 log units), on the high side, and the stated range covers the measured number.
By their numbers in this assay, from the lowest: compounds 3, 2 and 1 (each within the scatter of the next).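

On the aromatic carbon ortho to a methoxy group, the group of 8 heavy atoms, without the carbonyl double bond and with one hydrogen-bond acceptor fewer, takes the place of the group of 10 heavy atoms, and in this assay the result stays within the scatter (a 1.3-fold lower number from compound 2 to compound 3 (0.11 log units; within the scatter)). Lengthening the chain on its saturated carbon, three bonds along from the oxygen on the aromatic ring, is a separate single change and also stays within the scatter (a 1.7-fold lower number from compound 1 to compound 3 (0.22 log units; within the scatter)). Compounds 1, 2 and 3 therefore cannot be separated on this read-out, so neither the carbonyl nor the chain difference shows a measurable effect here, and nothing available offers an explanation for the numbers.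

The compounds shown leave open whether a longer chain, or an amide in place of the ether or carbonyl link, would move the number beyond the scatter. They also leave open what happens when sulfur stands in place of selenium at the chain end, or when the nitrile is replaced by an amine or a carboxylic acid.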